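This account rests on a few compounds, and the source may have more. Where it says the series, first, only, none or still open, it means among the compounds named here.

Of the compounds shown here, two sharing one core have been tested in a functional assay on HeLa cells (Homo sapiens) for cytotoxicity, read by MTT assay, with a stated time of 48 h, tested at 100 uM; a higher number here means a stronger effect of the compound at the concentration tested, a lower number a weaker effect. Compound 1 `CS(=O)(=O)c1ccc(Cc2n[nH]c(=S)n2/N=C/c2ccccc2Cl)cc1` carries a 2-chlorophenyl group, and in this assay compound 1 gives 76.5%. Compound 2 `CS(=O)(=O)c1ccc(Cc2n[nH]c(=S)n2/N=C/c2ccc(Cl)cc2)cc1` carries a 4-chlorophenyl group in its place, and in this assay compound 2 gives 57%. Within the data shown here, the single step between them is a number 19.5 percentage points lower from compound 1 to compound 2 (beyond the scatter). On the numbers shown, compound 2 therefore stands lowest of the two, with compound 1 as its only neighbour, a number beyond the scatter above it.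

Compound 3 `CS(=O)(=O)c1ccc(Cc2n[nH]c(=S)n2/N=C/c2c(F)cccc2Cl)cc1` has not yet been measured. The change from compound 2 to compound 3 is 2-chloro-6-fluorophenyl in place of 4-chlorophenyl on a carbon with a double bond to nitrogen. Among the measured compounds shown here, the only measured step that bears on this change is the one from compound 1 to compound 2, which put a chlorine at the 4-position in place of the 2-position and lowered the read-out modestly. Compound 3 returns a chlorine to the 2-position and adds a fluorine, so a rise of about the same size is expected, namely a number 18 percentage points higher from compound 2 to compound 3 (beyond the scatter). For compound 3 the estimated value is 75%, with a range from 55% to 92%.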

Compound 3, a percentage reported as activity, at one concentration (the size of the read-out at that concentration, not a potency): 77.3%
Compound 3: the middle estimate sits 2.3 percentage points below what was measured, and the stated range covers the measured number.
By their numbers in this assay, from the lowest: compound 2; then compounds 1 and 3 (each within the scatter of the next).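

In this assay, the move to the 2-chloro-6-fluorophenyl group gives a number 20.3 percentage points higher from compound 2 to compound 3 (beyond the scatter), so the drop seen with the 4-chlorophenyl group is not a fixed feature of the shared core: a different group on the same carbon, the one with a double bond to nitrogen, restores the higher read-out. The closer comparison is a number 0.8 percentage points higher from compound 1 to compound 3 (within the scatter), where fluoro stands in place of hydrogen on an aromatic carbon, so this added fluorine leaves no readable change, and the two groups that carry the 2-chloro pattern, 2-chlorophenyl and 2-chloro-6-fluorophenyl, both sit beyond the scatter above the 4-chlorophenyl group. Nothing shown here gives a reason for this difference between the groups.

From the compounds shown here alone, it remains open whether a 2-fluorophenyl group, with no chlorine at all, would match these two, and whether a different group on the ring, such as a methoxy group, an amine or a carboxylic acid, would keep the read-out at this level. Each read-out also comes from a single concentration, so these numbers show only a stronger or weaker effect at that concentration.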